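From compound 3 to compound 4: the pentyl change

The source may hold more compounds than are shown below. What is called first, only, known or untested is meant among the compounds shown, and "the series" means these compounds.

Measured in an ADME assay on a cell-free system (plasma, Homo sapiens), read by HPLC, with a stated time of 120 min, at 37 degrees C; a lower number here means that less of the compound is left, a higher number that more of the compound is left:
- compound 1 `CC(C)COC(=O)N1CCN(C(=O)c2nc(Nc3cc(C4CC4)[nH]n3)c3cc(Cl)ccc3n2)C[C@H]1C` gives 73.7%
- compound 2 `CC(C)C(=O)OCOC(=O)N1CCN(C(=O)c2nc(Nc3cc(C4CC4)[nH]n3)c3cc(Cl)ccc3n2)C[C@H]1C` gives 6.1%
- compound 3 `CC(OC(=O)N1CCN(C(=O)c2nc(Nc3cc(C4CC4)[nH]n3)c3cc(Cl)ccc3n2)C[C@H]1C)OC(=O)C(C)(C)C` gives 49.4%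

Compound 3 is the second highest of the three. The measured steps around it are a number 24.3 percentage points lower from compound 1 to compound 3 (beyond the scatter) and a number 43.3 percentage points higher from compound 2 to compound 3 (beyond the scatter), while a number 67.6 percentage points lower from compound 1 to compound 2 (beyond the scatter) spans the whole set.

Compound 4 `CCCCCOC(=O)N1CCN(C(=O)c2nc(Nc3cc(C4CC4)[nH]n3)c3cc(Cl)ccc3n2)C[C@H]1C` differs from compound 3 by pentyl in place of 1-(((tert-butyl)carbonyl)oxy)ethyl on an oxygen next to a carbonyl group.

Among the compounds with values here, the nearest precedent is compound 1, with isobutyl at that place and a value of 73.7%. A rise beyond the scatter in this assay is therefore expected, about as large as a number 24.3 percentage points lower from compound 1 to compound 3 (beyond the scatter) read in reverse. The expected change is a number 24.6 percentage points higher from compound 3 to compound 4 (beyond the scatter). Compound 4 is estimated at 74%, within an expected range of 58% to 90%.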

Compound 4, percent of the compound remaining: 74.4%
Beside the measured number, compound 4's estimate is 0.4 percentage points below it, and the stated range covers the measured number.
By their numbers in this assay, from the lowest: compound 2; then compound 3; then compounds 1 and 4 (each within the scatter of the next).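

In this assay the step of a number 0.7 percentage points higher from compound 1 to compound 4 (within the scatter) does not separate pentyl from isobutyl on an oxygen next to a carbonyl group. The steps of a number 25 percentage points higher from compound 3 to compound 4 (beyond the scatter) and a number 68.3 percentage points higher from compound 2 to compound 4 (beyond the scatter) place pentyl clear of both groups that hold a carbonyl in the chain, so the two plain alkyl chains now stand together in this set. No available evidence bears on what lies behind these numbers.

Open, as far as these compounds go, is whether a longer chain such as octyl, or a chain ending in an amine, would hold the level of compound 4 at this place.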